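A few compounds are considered here, and "the series" means these few. Any claim that something is new, unique, unknown or untested is made for them only; others in the source may bear on it.

Compound 2 `O=C(Nc1ccc(Cl)cc1)c1c(O)c2cccnc2n(-c2ccccc2)c1=O` stands highest of the three numbers in a functional assay on the whole organism for inhibition, with Rattus norvegicus as the target, read by paw edema, at a dose of 100 mg/kg by the oral route (a lower number here means less inhibition, a higher number more inhibition at the dose given (going by the name of the read-out)), with 11.6%, though only within the scatter of the rest. Compound 1 `CNC(=O)c1c(O)c2cccnc2n(-c2ccccc2)c1=O` gives 9.6% and compound 3 `O=C(Nc1nccs1)c1c(O)c2cccnc2n(-c2ccccc2)c1=O` gives 4.6%. Compound 4 `O=C(NCc1cccnc1)c1c(O)c2cccnc2n(-c2ccccc2)c1=O` carries the change ((pyridin-3-yl)methyl in place of 4-chlorophenyl on an amide-type nitrogen). Going by the values given here, the steps that bear on it, each also an exchange of the group on the amide-type nitrogen, are a number 2 percentage points higher from compound 1 to compound 2 (within the scatter), a number 7 percentage points lower from compound 2 to compound 3 (within the scatter) and a number 5 percentage points lower from compound 1 to compound 3 (within the scatter); none of them reaches beyond the scatter, and the whole series sits low in this assay. For compound 4 no step beyond the scatter is therefore expected, a number 2.6 percentage points lower from compound 2 to compound 4 (within the scatter). Compound 4 is estimated at 9%, with a range from 0% to 20%.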

Compound 4, a percentage reported as inhibition, in the whole organism at one dose (the size of the read-out at that dose, not a potency): 25.5%
Estimate against measurement, compound 4: 16.5 percentage points below; measured number outside the range, above it.
By their numbers in this assay, from the lowest: compounds 3, 1 and 2 (each within the scatter of the next); then compound 4.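

Going by these compounds alone, the group on the amide-type nitrogen can move the number in this assay: (pyridin-3-yl)methyl gives a number 13.9 percentage points higher from compound 2 to compound 4 (beyond the scatter), a number 20.9 percentage points higher from compound 3 to compound 4 (beyond the scatter) and a number 15.9 percentage points higher from compound 1 to compound 4 (beyond the scatter), the first steps at this position beyond the scatter. Methyl, 4-chlorophenyl and 1,3-thiazol-2-yl remain within the scatter of one another, so compound 4 alone stands apart. Nothing on hand explains the difference.

Open, on these data alone, is whether the step goes with the ring nitrogen or with the saturated chain carbon: benzyl and pyridin-3-yl directly on the amide-type nitrogen would separate the two.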